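The source may report more compounds than this note shows. Statements on the series, on what has been measured and on what is new or still open speak of the compounds shown alone.

Three compounds share one core and are joined through a saturated chain to a small nitrogen-rich group at the far end. Compound 1 `C/N=C(/NC#N)NCCCCCCn1nc(-c2ccccc2)ccc1=O` was tested in a functional assay on the whole organism (stomach) with Rattus norvegicus as the target; a higher number here means that more compound is needed for the effect, a lower number that less compound is needed. In this assay compound 1 gives > 100 mg/kg, which is a limit of the assay and not a number. Compound 2 `CC/N=C(/NC#N)NCCCCn1nc(-c2ccccc2)ccc1=O` in this assay gives 92 mg/kg. Compound 3 `CC/N=C(/NC#N)NCCCn1nc(-c2ccccc2)ccc1=O` in this assay gives 78.3 mg/kg. Compound 1 therefore stands at the edge of what the assay can report, and the one firm statement about it is the limit of > 100 mg/kg in this assay, at which 1 of the 3 values shown sits. Compound 4 `CN(C)/C(=N/CCCCCCn1nc(-c2ccccc2)ccc1=O)NC#N` has not yet been measured. It differs from compound 1 by a group of 8 heavy atoms (4 carbon, 4 nitrogen; no ring) in place of a group of 7 heavy atoms (3 carbon, 4 nitrogen; no ring), on a saturated chain carbon, six bonds along the chain from an aromatic nitrogen. Among the measured compounds shown here, no measured pair shows what this kind of change does, so the step is expected to stay within the usual scatter, with no clear direction. Compound 4 is expected to give 110 mg/kg in this assay, with a range from 50 mg/kg to 250 mg/kg. The step that the limit leaves unreadable from compound 1 to compound 4 is thus expected to be small, and a limit rather than a number may well be reported again.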

Compound 4, dose for half-maximal effect: 93.1 mg/kg
Compound 4: the middle estimate sits 1.2-fold (0.07 log units) above what was measured, and the stated range covers the measured number.
By their numbers in this assay, from the lowest: compounds 3, 2 and 4 (each within the scatter of the next). At a limit, above all of these: compound 1.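

In this assay, a group of 8 heavy atoms (4 carbon, 4 nitrogen; no ring) in place of a group of 7 heavy atoms (3 carbon, 4 nitrogen; no ring), on a saturated chain carbon, six bonds along the chain from an aromatic nitrogen, gives an at least 1.0-fold lower number from compound 1 to compound 4 (0.03 log units; that floor lies within the scatter). Among the compounds shown here, this is the first measured pair for this change at this position, and compound 4 gives an actual number, 93.1 mg/kg. The true size of the step stays unknown because compound 1 has a limit of the assay and not a number: the limit of > 100 mg/kg in this assay, at which 1 of the 4 values shown sits.

The compounds shown leave open whether the same change would act alike on the shorter chains of compound 2 and compound 3. They also leave open what an amine or a carboxylic acid in place of this end group would give in this assay.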